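Shifting the aryl on the piperazine nitrogen toward a single chlorine

A few compounds are considered here, and "the series" means these few. Any claim that something is new, unique, unknown or untested is made for them only; others in the source may bear on it.

Three compounds share one core and differ only in the aryl group on an amine nitrogen in a ring. Compound 1 `Nc1scc(CN2CCN(c3cccc(Cl)c3Cl)CC2)c1C(=O)c1ccc(Cl)cc1` gives -57% in a functional assay on CHO cells with adenosine receptor A1 (Homo sapiens) as the target, read by cAMP accumulation and immunoassay, with a stated time of 6 min, tested at 1 uM; on this read-out lower numbers stand for a stronger effect and higher numbers for a weaker effect at the one concentration tested. Compound 2 `Nc1scc(CN2CCN(c3ccccc3F)CC2)c1C(=O)c1ccc(Cl)cc1` gives -9.2% in this assay. Compound 3 `Nc1scc(CN2CCN(c3ccc(F)c(F)c3)CC2)c1C(=O)c1ccc(Cl)cc1` gives -78% in this assay, the lowest of the three numbers; the steps of a number 21 percentage points lower from compound 1 to compound 3 (beyond the scatter) and a number 68.8 percentage points lower from compound 2 to compound 3 (beyond the scatter) both lie beyond the scatter.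

Compound 4 `Nc1scc(CN2CCN(c3ccccc3Cl)CC2)c1C(=O)c1ccc(Cl)cc1` is not yet measured. It differs from compound 3 by 2-chlorophenyl in place of 3,4-difluorophenyl on an amine nitrogen in a ring. The step that bears most on it is a number 68.8 percentage points lower from compound 2 to compound 3 (beyond the scatter), which runs in the opposite direction from the change considered here; a number 47.8 percentage points higher from compound 1 to compound 2 (beyond the scatter) shows how far a phenyl carrying a single halogen can move the number upward. A large upward step is therefore expected for compound 4, namely a number 50 percentage points higher from compound 3 to compound 4 (beyond the scatter). Compound 4 is estimated at -28%, with a range from -62% to 5%.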

Compound 4, a percentage reported as activity, at one concentration (the size of the read-out at that concentration, not a potency): -5.2%
Beside the measured number, compound 4's estimate is 22.8 percentage points below it; low and high end bracket the measured number.
By their numbers in this assay, from the lowest: compound 3; then compound 1; then compounds 2 and 4 (each within the scatter of the next).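

In this assay, the 2-chlorophenyl of compound 4 and the 2-fluorophenyl of compound 2 cannot be told apart, since a number 4 percentage points higher from compound 2 to compound 4 (within the scatter), so chloro in place of fluoro on this aromatic carbon registers no change. The second halogen carries far more weight here: hydrogen in place of chloro gives a number 51.8 percentage points higher from compound 1 to compound 4 (beyond the scatter), and the change of the whole aryl group gives a number 72.8 percentage points higher from compound 3 to compound 4 (beyond the scatter), leaving the two phenyls with a single halogen apart from the two with a pair, with no listed compound against this. The data offer no explanation for these steps.

The compounds shown leave open whether a single halogen elsewhere on the ring, as in 3-chlorophenyl or 4-fluorophenyl, would behave like the pairs. They also leave open what an unsubstituted phenyl or a methoxy group would give.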